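A few compounds are considered here, and "the series" means these few. Any claim that something is new, unique, unknown or untested is made for them only; others in the source may bear on it.

Working notes on the series. In a functional assay on MCF7 cells (Homo sapiens) for cytotoxicity, read by MTT assay, with a stated time of 48 h (on this read-out lower numbers stand for stronger inhibition and higher numbers for weaker inhibition), compound 1 (`Cc1ccccc1-c1nnc(SCCn2c([N+](=O)[O-])cnc2C)o1`) gives 15800 nM while compound 2 (`CCOc1ccc(-c2nnc(SCCn3c([N+](=O)[O-])cnc3C)o2)cc1`) gives 16600 nM and compound 3 (`Cc1ncc([N+](=O)[O-])n1CCSc1nnc(-c2ccc([N+](=O)[O-])cc2)o1`) gives 12700 nM on the same read-out. Compound 3 therefore stands level with the other two, as all three numbers lie within the scatter of one another. The next compound is compound 4 (`Cc1ncc([N+](=O)[O-])n1CCSc1nnc(-c2ccc(Cl)cc2)o1`), with chloro in place of nitro on an aromatic carbon, para to a large group (chloro in place of nitro on an aromatic carbon). Among the measured compounds shown here, the one measured step at that carbon, nitro in place of ethoxy (a 1.3-fold lower number from compound 2 to compound 3 (0.12 log units; within the scatter)), stays within the scatter, so no shift beyond the scatter is expected in this assay for the new exchange. Chloro itself has not yet been measured in the series, so this expectation rests on a single step. The estimated change is small (a 1.1-fold higher number from compound 3 to compound 4 (0.04 log units; within the scatter)) and is not expected to exceed the scatter. Compound 4 is estimated at 14000 nM with an expected range from 7000 nM to 28000 nM on this read-out.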

Compound 4, half-maximal inhibitory concentration: 18700 nM
For compound 4 the middle estimate is 1.3-fold (0.13 log units) below the measured one; measured number inside the range.
By their numbers in this assay, from the lowest: compounds 3, 1, 2 and 4 (each within the scatter of the next).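

In this assay, the aromatic carbon para to a large group now carries a third group, and chloro in place of nitro gives a 1.5-fold higher number from compound 3 to compound 4 (0.17 log units; within the scatter), while chloro in place of ethoxy gives a 1.1-fold higher number from compound 2 to compound 4 (0.05 log units; within the scatter), so nitro, ethoxy and chloro at this carbon cannot be ranked. The exchange of 2-methylphenyl for 4-chlorophenyl gives a 1.2-fold higher number from compound 1 to compound 4 (0.07 log units; within the scatter), so this change of aryl group also leaves the read-out unresolved. No measurement at hand offers an explanation for these numbers.

Going by these compounds, whether any group on this carbon can move the number beyond the scatter remains open. An amine or a carboxylic acid there, or a longer chain in place of ethoxy, would test this.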